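Chloromethyl ketone thioether chain length in the series

The source may report more compounds than this note shows. Statements on the series, on what has been measured and on what is new or still open speak of the compounds shown alone.

Measured so far in a functional assay on NALM-6 cells (Homo sapiens); on this read-out higher numbers stand for weaker inhibition and lower numbers for stronger inhibition:
Compound 1 `CCCCSC[C@H](NC(C)=O)C(=O)CCl`: 41400 nM
Compound 2 `CCCCCSC[C@H](NC(C)=O)C(=O)CCl`: 5800 nM
Compound 3 `CCCCCCCCCCCCCSC[C@H](NC(C)=O)C(=O)CCl`: > 100000 nM, which for compound 3 is a limit of this assay, not a number.

Among the compounds with values here, the only counted change from compound 1 to compound 2 is methyl in place of hydrogen on a saturated chain carbon, four bonds along the chain from a sulfur and it gives a 7.1-fold lower number from compound 1 to compound 2 (0.85 log units; beyond the scatter). Extending further, an at least 17-fold higher number from compound 2 to compound 3 (1.23 log units; beyond the scatter), the value for compound 3 sitting at the limit of > 100000 nM in this assay, at which 1 of the 3 values shown sits. The difference between the core of compound 1 and the core of compound 3 is not broken down here.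

Compound 4 `CCCCCCCCCCCCCCSC[C@H](NC(C)=O)C(=O)CCl` is not yet measured. Within the data shown here, its change from compound 3 is methyl in place of hydrogen on a saturated chain carbon, ten or more bonds along the chain from a sulfur, the same kind of change as the one from compound 1 to compound 2, but the place along the chain differs, as the two counted differences show. Since compound 3 already sits at a limit in this assay and the step from compound 2 to compound 3 was large, compound 4 is expected to change little, a step that the limit leaves unreadable from compound 3 to compound 4, and most likely to be reported as a limit again. The estimate for compound 4 in this assay is 150000 nM, between 50000 nM and 600000 nM.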

Compound 4, half-maximal inhibitory concentration: 8700 nM
The estimate for compound 4 lay 17-fold (1.24 log units) above the measured number, outside the stated range (below it).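

In this assay, methyl in place of hydrogen on a saturated chain carbon gives an at least 11-fold lower number from compound 3 to compound 4 (1.06 log units; beyond the scatter), and the change points the same way on both cores: the same change on two cores in this assay, a 7.1-fold lower number (0.85 log units; beyond the scatter) from compound 1 to compound 2 and an at least 11-fold lower number (1.06 log units; beyond the scatter) from compound 3 to compound 4; the limit leaves it open whether they differ Compound 3 is reported only as a limit of the assay, not as a number: the limit of > 100000 nM in this assay, at which 1 of the 4 values shown sits. The direction therefore carries across these two cores, but the size of the step on the second core stays unfixed, and two cases do not establish a rule for other chain places.

Open, as far as these compounds go, is how the number runs through thioethers with a hexyl or a decyl chain. Also open, from the compounds shown here alone, is whether the chain trend survives a carboxylic acid in place of the chloromethyl ketone.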